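Histamine antagonist series: aryl swap on the chain carbon

The compounds below may be only part of what the source reports. "The series", "measured", "known", "first", "only" and "open" are said of these compounds alone.

Of the compounds shown here, three of one shared core have been measured in a functional assay on ileum for antagonist activity at histamine H1 receptor (Cavia porcellus); a lower number here means tighter binding, a higher number weaker binding. Compound 1 `N=C(NCCCc1c[nH]cn1)NCCSC(c1ccccc1)c1ccccn1` gives 100 nM in this assay. Compound 2 `N=C(NCCCc1c[nH]cn1)NCCCC(c1ccccc1)c1ccccn1` gives 251 nM. Compound 3 `N=C(NCCCc1c[nH]cn1)NCCC(c1ccc(Br)cc1)c1ccccn1` gives 120 nM, the second highest of the three numbers; its nearest neighbour is compound 1, whose value lies within the usual scatter of that of compound 3, while the value of compound 2 lies beyond it. For the measured compounds named here, no two of the three differ in only one place, so no single step within the measured set can be isolated.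

Compound 4 `N=C(NCCCc1c[nH]cn1)NCCC(c1ccccn1)c1cccs1` is not yet measured. It differs from compound 3 in one place: thiophen-2-yl in place of 4-bromophenyl on a saturated chain carbon bound to an aromatic carbon and a saturated chain carbon. Going by the values given here, since no measured pair shows the effect of such a change, the expectation rests on the spread of the three values alone, all of which fall within a narrow band. The step from compound 3 to compound 4 is expected to be small, most likely within the scatter or at most a modest shift toward a higher number, as a 1.3-fold higher number from compound 3 to compound 4 (0.10 log units; within the scatter). Compound 4 is therefore estimated to give about 150 nM in this assay, with a plausible range from 50 nM to 450 nM.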

Compound 4, dissociation constant: 45.7 nM
Estimate against measurement, compound 4: 3.3-fold (0.52 log units) above; the measured number lies below the stated range.
By their numbers in this assay, from the lowest: compound 4; then compounds 1 and 3 (each within the scatter of the next); then compound 2.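

In this assay, thiophen-2-yl in place of 4-bromophenyl on a saturated chain carbon bound to an aromatic carbon and a saturated chain carbon gives a 2.6-fold lower number from compound 3 to compound 4 (0.42 log units; beyond the scatter). For the compounds shown here, this is the only single-place step so far, and it shows that the number responds to the group at this position, which the earlier compounds could not show. The swap changes several things at once, from a six-membered aromatic ring of carbon only with bromine to a five-membered aromatic ring with 1 hetero atom, with fewer heavy atoms and 1 hydrogen-bond acceptor instead of 0, and nothing available explains the step or assigns it to any one of these differences.

As far as these compounds go, it remains open whether the step follows from the loss of bromine or from the change of ring, and a plain phenyl or a furan-2-yl group on the same carbon would help separate the two. Also open, from the compounds shown here alone, is whether the step holds on the other linkers, such as the sulfur-containing chain of compound 1 or the longer chain of compound 2.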